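Shortening the amine-bearing chain on a shared core

The compounds below may be only part of what the source reports. "The series", "measured", "known", "first", "only" and "open" are said of these compounds alone.

Compound 1 `OCCCCNc1nnc(-c2ccc(F)c(F)c2Nc2ccc(I)cc2F)o1`: < 3 ug/mL
Compound 2 `NCCCNc1nnc(-c2ccc(F)c(F)c2Nc2ccc(I)cc2F)o1`: 5.4 ug/mL
Compound 3 `OCCNc1nnc(-c2ccc(F)c(F)c2Nc2ccc(I)cc2F)o1`: < 3 ug/mL

The three measured compounds share one core and differ only in the chain carried by the nitrogen on the aromatic ring. Among the measured compounds shown here, in a physicochemical assay for solubility, read by HPLC, in phosphate buffer, at pH 6.5 (on this read-out higher numbers stand for higher solubility and lower numbers for lower solubility), compound 2 gives 5.4 ug/mL, the only number among the three. For compound 1 this assay reports only a limit, < 3 ug/mL. For compound 3 it likewise reports only a limit, < 3 ug/mL. Both compound 1 and compound 3 thus rest at the limit of < 3 ug/mL in this assay, at which 2 of the 3 values shown sit.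

Compound 4 `NCCNc1nnc(-c2ccc(F)c(F)c2Nc2ccc(I)cc2F)o1` has not yet been measured. It differs from compound 2 in one place: amino in place of aminomethyl on a saturated chain carbon, two bonds along the chain from a nitrogen on an aromatic ring.

Of the measured steps, an at least 1.8-fold higher number from compound 1 to compound 2 (0.25 log units; that floor lies within the scatter) and an at least 1.8-fold lower number from compound 2 to compound 3 (0.25 log units; that floor lies within the scatter) exchange an amine-bearing chain for a hydroxy-bearing one, which is not the change at hand. The closest parallel, a shortening of a hydroxy chain, is a step that the two limits leave unreadable from compound 1 to compound 3, and its size cannot be read. For the measured compounds named here, no measured step follows the change from compound 2 to compound 4 closely. The expectation is therefore no step beyond the scatter: a 1.1-fold higher number from compound 2 to compound 4 (0.05 log units; within the scatter). For compound 4 the estimate is 6 ug/mL, with a range from 2.5 ug/mL to 15 ug/mL. Since two of the three values sit at a limit, a limit rather than a number for compound 4 is a real possibility.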

Compound 4, solubility: < 3 ug/mL
Compound 4 ended at the assay's limit; the forecaster's own chance of this, stated with the estimate: 30%; at least 2.0-fold (0.30 log units) between middle value and limit.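

Moving from 3-aminopropyl to 2-aminoethyl on the shared core gives an at least 1.8-fold lower number from compound 2 to compound 4 (0.25 log units; that floor lies within the scatter), so the printed floor for this change does not by itself clear the scatter. Among the compounds shown here, the earlier compounds left open whether an amino group at the end of the chain was enough to give a readable number, since the only contrast available set compound 2 against hydroxy chains. Compound 4 carries an amino group on its chain and still gives no number in this assay, so among the four compounds an amine-bearing chain does not go with a readable value in every case, and compound 2 stands alone: the limit of < 3 ug/mL in this assay, at which 3 of the 4 values shown sit.

The steps linking compound 4 to compound 1 and to compound 3 cannot be read, as both ends of each are limits. The compounds shown leave open how far under its limit compound 4 lies, and how a longer chain such as 4-aminobutyl, or a chain ending in a dimethylamino group or a carboxylic acid, would read in this assay.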